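Trading a 4-chlorophenyl for an alkyl tail

This account rests on a few compounds, and the source may have more. Where it says the series, first, only, none or still open, it means among the compounds named here.

Of the compounds shown here, two have been measured in a functional assay on cells (T-cell line, Homo sapiens) for inhibition; a higher number here means a weaker inhibitor, a lower number a stronger inhibitor. Compound 1 `COc1ccc(CCCN2CCC(COCc3ccccc3)CC2)cc1` gives 2100 nM in this assay. Compound 2 `Clc1ccc(CCCN2CCC(COC(c3ccccc3)c3ccccc3)CC2)cc1` gives 500 nM in this assay, the lower of the two numbers, and its gap to compound 1 lies beyond the scatter. Compound 2 and compound 1 differ in more than one place, so their values are simply set side by side.

Compound 3 `CCCCCN1CCC(COC(c2ccccc2)c2ccccc2)CC1` has not yet been measured. ethyl in place of 4-chlorophenyl on a saturated chain carbon, three bonds along the chain from an amine nitrogen in a ring The 4-chlorophenyl that leaves brings one six-membered aromatic ring of carbon only, while the ethyl that enters has no ring. Among the measured compounds shown here, no measured pair shows what such a change does here, so any step is an expectation rather than a reading of the data. The step of a 3.0-fold higher number from compound 2 to compound 3 (0.48 log units; beyond the scatter) is expected to raise the number somewhat beyond the scatter. In this assay compound 3 is estimated at 1500 nM, in a range from 500 nM to 5000 nM.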

Compound 3, half-maximal inhibitory concentration: 10800 nM
The estimate for compound 3 lay 7.2-fold (0.86 log units) below the measured number; the measured number lies above the stated range.
By their numbers in this assay, from the lowest: compound 2; then compound 1; then compound 3.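

In this assay, among the compounds shown here, ethyl in place of 4-chlorophenyl gives a 22-fold higher number from compound 2 to compound 3 (1.33 log units; beyond the scatter) and so provides the first reading at this position, on a saturated chain carbon, three bonds along the chain from an amine nitrogen in a ring. With the rest of the structure unchanged, going from 3-(4-chlorophenyl)propyl to pentyl costs a large step in this assay, so the group at this place weighs heavily on the number. Nothing available explains the size of this step.

The compounds shown leave open whether the chlorine, the aromatic ring or simply the larger group carries the difference. Going by these compounds, a plain phenyl and a cyclohexyl at this position would each separate these possibilities, and how either would read in this assay remains unknown.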